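Acid-bearing biaryl replacement in the imidazole series

This account rests on a few compounds, and the source may have more. Where it says the series, first, only, none or still open, it means among the compounds named here.

Compound 2 `CCC(C)(C)Cc1c[nH]c(CCc2ccc(-c3cnsc3)cc2)n1` gives 10 nM in an in vitro assay on CHO cells for displacement of a labelled ligand from Bombesin receptor subtype-3 (Homo sapiens), read by scintillation counting, with a stated time of 2 h; on this read-out higher numbers stand for weaker inhibition and lower numbers for stronger inhibition. Among the three measured compounds it holds the second highest number: compound 1 `CCC(C)(C)Cc1c[nH]c(CCc2ccc(-c3cccnc3)cc2)n1` gives 7.5 nM, and compound 3 `O=C(O)c1cc(F)c(F)cc1-c1ccc(CCc2nc(CC3CCCCC3)c[nH]2)cc1` gives 36 nM, a higher number than compound 2 and beyond the scatter, whereas the gap to compound 1 lies within it.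

The step to compound 4 `CCC(C)(C)Cc1c[nH]c(CCc2ccc(-c3cccnc3C(=O)O)cc2)n1` is 2-carboxypyridin-3-yl in place of 1,2-thiazol-4-yl on an aromatic carbon. For the measured compounds named here, only one measured step bears on it: a 1.3-fold higher number from compound 1 to compound 2 (0.12 log units; within the scatter), which shows that exchanging the pyridin-3-yl for the 1,2-thiazol-4-yl made no difference beyond the scatter. Returning to a pyridine is therefore expected to be neutral; the added carboxy group has no direct precedent in the series, since compound 3 carries its acid on a different ring and a different core, and its value can only be noted as higher than that of compound 2. A small weakening is estimated, a 2.0-fold higher number from compound 2 to compound 4 (0.30 log units; within the scatter), within or near the scatter.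

Compound 4 is expected to give 20 nM in this assay, with a range of 6 nM to 65 nM.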

Compound 4, half-maximal inhibitory concentration: 560 nM
Beside the measured number, compound 4's estimate is 28-fold (1.45 log units) below it; the whole stated range lies below it.
By their numbers in this assay, from the lowest: compounds 1 and 2 (each within the scatter of the next); then compound 3; then compound 4.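

Adding a carboxy group to the pyridin-3-yl ring of compound 1 gives a 75-fold higher number from compound 1 to compound 4 (1.87 log units; beyond the scatter) in this assay, whereas the ring exchange a 1.3-fold higher number from compound 1 to compound 2 (0.12 log units; within the scatter) stayed within the scatter. The exchange of 1,2-thiazol-4-yl for 2-carboxypyridin-3-yl gives a 56-fold higher number from compound 2 to compound 4 (1.75 log units; beyond the scatter) and so points the same way: this position accepts either unsubstituted ring, but not the pyridine carrying this carboxy group. No supporting data are available to explain the loss.

From the compounds shown here alone, it remains open whether the loss is specific to the carboxylic acid or extends to other groups on the same ring carbon, such as a methyl ester, a primary amide or a hydroxymethyl group. Equally open, going by these compounds, is whether a carboxylic acid at another carbon of the pyridine ring would give a similar result.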